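Ether for Methylamine Linker: Expected Efficacy of Compound 4

The source may report more compounds than this note shows. Statements on the series, on what has been measured and on what is new or still open speak of the compounds shown alone.

Compound 1, `CC(C)c1onc(-c2c(Cl)cccc2Cl)c1COc1ccc(NC(=O)c2ccc(C(=O)O)cc2)c(C(F)(F)F)n1`: 109%
Compound 2, `CN(Cc1ccc(C(=O)NCCS(=O)(=O)O)cc1)c1ccc(OCc2c(-c3c(Cl)cccc3Cl)noc2C2CC2)nc1C(F)(F)F`: 105%
Compound 3, `CC(c1ccc(OCc2c(-c3c(Cl)cccc3Cl)noc2C2CC2)nc1C(F)(F)F)N(C)c1ccc(C(=O)O)cc1`: 102%

In an assay on isolated protein for agonist activity at Bile acid receptor (Homo sapiens), read by FRET (on this read-out lower numbers stand for smaller maximal responses and higher numbers for larger maximal responses), all three measured compounds reach roughly the full response of the reference. Compound 3 sits at one end of this narrow span, yet its gaps to compound 2 and to compound 1 both lie within the usual scatter, so the three cannot be told apart on these numbers.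

Compound 4, `CC(Oc1ccc(C(=O)O)cc1)c1ccc(OCc2c(-c3c(Cl)cccc3Cl)noc2C2CC2)nc1C(F)(F)F`, differs from compound 3 in one place: 4-carboxyphenoxy in place of (4-carboxyphenyl)(methyl)amino on a saturated chain carbon bound to an aromatic carbon and a saturated chain carbon. Going by the values given here, since no step between measured compounds is known for this assay, the expectation rests on the shared behaviour of the three: compound 4 is expected to remain a full agonist, with a step from compound 3 of a number 2 percentage points lower from compound 3 to compound 4 (within the scatter), none beyond the scatter. The estimated value of compound 4 is 100%, ranging from 85% to 115%.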

Compound 4, largest response reached (reported as efficacy), in percent of the reference or control that the assay uses: 89%
For compound 4 the middle estimate is 11 percentage points above the measured one; low and high end bracket the measured number.
By their numbers in this assay, from the lowest: compound 4; then compounds 3, 2 and 1 (each within the scatter of the next).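

On the saturated chain carbon bound to an aromatic carbon and a saturated chain carbon, the exchange of groups does register in this assay: with 4-carboxyphenoxy in place of (4-carboxyphenyl)(methyl)amino, the maximal response comes out a number 13 percentage points lower from compound 3 to compound 4 (beyond the scatter) and so separates two compounds, which the earlier values could not do. No measurement at hand bears on why this happens. Still open, going by these compounds, is how a thioether or a plain methylene link at this place would compare with these two groups, and whether the same exchange would lower the response on another core.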